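Octyl in place of 2-fluorophenyl on the triazole carbon

This account rests on a few compounds, and the source may have more. Where it says the series, first, only, none or still open, it means among the compounds named here.

Three compounds share a core and differ at one carbon of the five-membered ring. Compound 1 `CCCCCCc1cn(C(c2ccccc2)c2cc3cc(Br)ccc3nc2OC)nn1` gives -0.97% in an ADME assay on HeLa cells (Homo sapiens) for cytotoxicity, read by sulforhodamine B assay, with a stated time of 48 h, tested at 10 uM; a lower number here means less inhibition, a higher number more inhibition at the concentration tested (going by the name of the read-out). Compound 2 `COc1nc2ccc(Br)cc2cc1C(c1ccccc1)n1cc(-c2ccccc2)nn1` gives 13.9%, and compound 3 `COc1nc2ccc(Br)cc2cc1C(c1ccccc1)n1cc(-c2ccccc2F)nn1` gives 14.1%. Compound 3 sits above compound 1 beyond the scatter, while its gap to compound 2 is within the scatter, so no order between compounds 2 and 3 is claimed.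

Compound 4 `CCCCCCCCc1cn(C(c2ccccc2)c2cc3cc(Br)ccc3nc2OC)nn1` is not yet measured. It differs from compound 3 as follows: octyl in place of 2-fluorophenyl on an aromatic carbon. Among the measured compounds shown here, the steps that bear on this are the chain-to-ring changes already measured: a number 15.1 percentage points higher from compound 1 to compound 3 (beyond the scatter) and a number 14.9 percentage points higher from compound 1 to compound 2 (beyond the scatter), both modest and both beyond the scatter. For the measured compounds named here, the present step goes the other way, from a ring back to a chain, with octyl instead of hexyl; no measured pair separates hexyl from octyl. A fall of about the size seen from compound 1 to compound 3 is therefore expected. The expected step is a number 13.1 percentage points lower from compound 3 to compound 4 (beyond the scatter). Compound 4 is estimated at 1%, with a range from -10% to 12%.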

Compound 4, a percentage reported as inhibition, at one concentration (the size of the read-out at that concentration, not a potency): 0.1%
Estimate against measurement, compound 4: 0.9 percentage points above; the measured number falls inside the stated range.
By their numbers in this assay, from the lowest: compounds 1 and 4 (each within the scatter of the next); then compounds 2 and 3 (each within the scatter of the next).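

In this assay, octyl stands apart from both aromatic rings at this carbon: a number 14 percentage points lower from compound 3 to compound 4 (beyond the scatter) and a number 13.8 percentage points lower from compound 2 to compound 4 (beyond the scatter), so the gap first seen with hexyl also appears with a second chain. Hexyl and octyl are not told apart, with a number 1.1 percentage points higher from compound 1 to compound 4 (within the scatter), and the four compounds therefore fall into two sets, chains and aromatic rings, at this position. Nothing measured here gives a reason for this split.

The compounds shown leave open whether methyl or a chain longer than octyl would read with hexyl and octyl, and whether a phenyl bearing an amine or a carboxylic acid would read with phenyl and 2-fluorophenyl. They also leave open whether cyclohexyl, a ring without aromatic character, would fall with the chains or with the aromatic rings.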